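The compounds below may be only part of what the source reports. "The series", "measured", "known", "first", "only" and "open" are said of these compounds alone.

Working notes on the series. For the measured compounds named here, compound 1 `C=Cc1cn([C@H]2C[C@H](O)[C@@H](CO)O2)c(=O)[nH]c1=O` gives 14200 nM in an ADME assay on L1210/0 cells (Mus musculus) for cytotoxicity, with a stated time of 48 h (a lower number here means a stronger inhibitor, a higher number a weaker inhibitor), the highest of the two numbers so far; compound 2 `CC(=O)OCCOCn1cnc2c(=S)[nH]c(N)nc21`, the nearest, gives 3200 nM in this assay, a gap beyond the scatter, but no step between the two can be traced to a single structural change. Compound 3 `C=CC#Cc1cn([C@H]2C[C@H](O)[C@@H](CO)O2)c(=O)[nH]c1=O` is not yet measured in this assay. It differs from compound 1 by a group of 4 heavy atoms (4 carbon; no ring) in place of a group of 2 heavy atoms (2 carbon; no ring), on an aromatic carbon. Going by the values given here, no measured step covers a change of this kind, so the expected step of a 1.8-fold lower number from compound 1 to compound 3 (0.25 log units; within the scatter) is a modest one, toward a lower number, with wide uncertainty. For compound 3 the estimate is 8000 nM, within 2000 nM to 40000 nM.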

Compound 3, half-maximal inhibitory concentration: > 200000 nM
Compound 3: only a limit was reported (the forecaster's own chance of this, stated with the estimate: 5%); at least 25-fold (1.39 log units) between middle value and limit.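

For the compounds shown here, at this aromatic carbon, the group of 4 heavy atoms in place of vinyl gives an at least 14-fold higher number from compound 1 to compound 3 (1.14 log units; beyond the scatter), the first traceable step, and it shows that this position does not tolerate every all-carbon group in this assay. The size of this step has a floor but no ceiling, since compound 3 sits at a limit of the assay and not at a number: the limit of > 200000 nM in this assay, at which 1 of the 3 values shown sits.

The compounds shown leave open whether the higher number goes with the triple bond or with the longer chain. An ethynyl group or a saturated butyl chain on this aromatic carbon would separate the two.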